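Swapping an oxygen ring for a sulfur ring on a pyrazoline sulfone

The compounds below may be only part of what the source reports. "The series", "measured", "known", "first", "only" and "open" are said of these compounds alone.

Measured compounds:
Compound 1, `COc1ccc(C2=NN(c3ccccc3)C(c3ccc(C)cc3)C2S(=O)(=O)CC2=NCCO2)cc1`, 64.3%
Compound 2, `O=S(=O)(CC1=NCCO1)c1n[nH]cc1-c1ccc(Cl)cc1`, "not active" (no number reported)
Compound 3, `COc1ccc(C2=NN(c3ccccc3)C(c3ccc(C)cc3)C2S(=O)(=O)CC2=NCCS2)cc1`, 43.9%

In a functional assay, tested at 75 ug/mL (a lower number here means a weaker effect, a higher number a stronger effect of the compound at the concentration tested), compound 1 gives 64.3%. Compound 3 differs from compound 1 by a group of 5 heavy atoms (3 carbon, 1 nitrogen, 1 sulfur; one five-membered non-aromatic ring with 2 hetero atoms) in place of a group of 5 heavy atoms (3 carbon, 1 nitrogen, 1 oxygen; one five-membered non-aromatic ring with 2 hetero atoms), on a saturated chain carbon bound to a sulfonyl sulfur, and this change costs activity: a number 20.4 percentage points lower from compound 1 to compound 3 (beyond the scatter). Compound 2 has a different core from compound 1; the difference between the two cores is not broken down here. In this assay compound 2 is reported as "not active" (no number reported), with no number attached.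

Compound 4, `O=S(=O)(CC1=NCCS1)c1n[nH]cc1-c1ccc(Cl)cc1`, has not yet been measured. It stands to compound 2 as compound 3 stands to compound 1: the change is a group of 5 heavy atoms (3 carbon, 1 nitrogen, 1 sulfur; one five-membered non-aromatic ring with 2 hetero atoms) in place of a group of 5 heavy atoms (3 carbon, 1 nitrogen, 1 oxygen; one five-membered non-aromatic ring with 2 hetero atoms), on a saturated chain carbon bound to a sulfonyl sulfur, the same change as before, made at the same place. Since the change weakened the effect when made on compound 1, and compound 2 itself shows no effect, compound 4 is expected to remain without measurable activity, with an estimated read-out in this assay of 5%, in the range 0% to 20%.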

Compound 4, a percentage reported as activity, at one concentration (the size of the read-out at that concentration, not a potency): "not active" (no number reported)
Nothing numeric was reported for compound 4; the estimate stays without a comparison.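

Compound 2 and compound 4 are both reported without a number in this assay, so no step can be read between them. The compounds shown leave open whether swapping the oxygen ring for the sulfur ring changes the effect at all on the core of compound 2. No other data here bear on this result.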